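The compounds below may be only part of what the source reports. "The series", "measured", "known", "first", "only" and "open" are said of these compounds alone.

The measured compounds:

Compound 1, `CC1=C(C(=O)OC(C)(C)C)C(c2ccsc2)NC(=O)N1`: in an assay on membranes from HEK293 cells for displacement of a labelled ligand from adenosine receptor A2b (Homo sapiens), read by scintillation counting, with a stated time of 30 min, tested at 1 uM (on this read-out lower numbers stand for less inhibition and higher numbers for more inhibition at the one concentration tested (going by the name of the read-out)), compound 1 gives 47%.
Compound 2, `CC1=C(C(=O)OCc2ccccc2)C(c2ccsc2)NC(=O)N1`: in this assay compound 2 gives 44%.
Compound 3, `CC1=C(C(=O)OC(C)(C)C)C(c2ccco2)NC(=S)N1`: in this assay compound 3 gives 9%.

Compounds 1 and 2 share one core and differ in a single place, (benzyl in place of tert-butyl on an oxygen next to a carbonyl group). That change made a step of a number 3 percentage points lower from compound 1 to compound 2 (within the scatter), so the two compounds cannot be told apart by this read-out. Compound 3 is built on a different core; how the two cores differ is not broken down here. What is clear is that compound 3 sits far below both: compound 2 stands a good deal higher, and compound 1 higher still, in each case beyond the scatter.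

Compound 4, `CC1=C(C(=O)OCc2ccccc2)C(c2ccco2)NC(=S)N1`, has not yet been measured in this assay. It stands to compound 3 as compound 2 stands to compound 1: the change is benzyl in place of tert-butyl on an oxygen next to a carbonyl group, the same change made at the same place. Because the earlier step, a number 3 percentage points lower from compound 1 to compound 2 (within the scatter), stayed within the scatter, a similarly small step is expected here, leaving compound 4 close to where compound 3 stands. The expected step from compound 3 to compound 4 is no change at the digits printed from compound 3 to compound 4 (within the scatter). For compound 4 the estimate in this assay is 9%, with a likely range from 0% to 22%.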

Compound 4, a percentage reported as inhibition, at one concentration (the size of the read-out at that concentration, not a potency): 41%
The estimate for compound 4 lay 32 percentage points below the measured number; the whole stated range lies below it.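

Putting benzyl in place of tert-butyl on an oxygen next to a carbonyl group does not work as a fixed shift that can be carried from one core to another: on the core of compound 3, this assay shows a number 32 percentage points higher from compound 3 to compound 4 (beyond the scatter). On the core of compound 1 the same change left no step that could be told from scatter, so the result depends on the core that carries the change, and the two steps are clearly different: the same change on two cores in this assay, a number 3 percentage points lower (within the scatter) from compound 1 to compound 2 and a number 32 percentage points higher (beyond the scatter) from compound 3 to compound 4, 35 percentage points apart, beyond the scatter of two such steps

What this does not show is which part of the difference between the two cores matters, or why the step appears on one core and not on the other, and two pairs of compounds are too few to give a rule for any further core.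

As far as these compounds go, only tert-butyl and benzyl appear on this oxygen, so it remains open how a methyl group, a longer chain, or a benzyl ring carrying an amine would read on either core. From the compounds shown here alone, it also remains open how the same change would behave on a core that combines parts of the core of compound 1 and the core of compound 3.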